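Notes on the amide substituent, compound 2 to compound 3

The compounds below may be only part of what the source reports. "The series", "measured", "known", "first", "only" and "open" are said of these compounds alone.

Measured in a physicochemical assay for lipophilicity, at pH 7.4; a lower number here means a more polar compound, a higher number a more lipophilic compound:
Compound 1 `COc1ccc(NC(=O)[C@H]2CCCN2C(=O)C2(c3cccc(Cl)c3)CCCC2)nc1`: 6.8
Compound 2 `O=C(Nc1ccc2[nH]ccc2n1)[C@H]1CCCN1C(=O)C1(c2cccc(Cl)c2)CCCC1`: 5.9

Compound 2 holds the lower of the two numbers in this assay. Compound 3 `O=C(Nc1ccc2[nH]c(=O)[nH]c2c1)[C@H]1CCCN1C(=O)C1(c2cccc(Cl)c2)CCCC1` is not yet measured and differs from compound 2 by a group of 10 heavy atoms (7 carbon, 2 nitrogen, 1 oxygen; one five-membered aromatic ring with 2 hetero atoms, one six-membered aromatic ring of carbon only) in place of a group of 9 heavy atoms (7 carbon, 2 nitrogen; one five-membered aromatic ring with 1 hetero atom, one six-membered aromatic ring with 1 hetero atom), on an amide-type nitrogen. Going by the values given here, the only measured step at this place is a number 0.90 log units lower from compound 1 to compound 2 (beyond the scatter). Among the compounds with values here, that single step is modest and shows no trend, but it is the sole guide, so another modest move to a lower number is expected. The expected change is a number 0.50 log units lower from compound 2 to compound 3 (beyond the scatter). For compound 3 the estimate is 5.4, with an expected range of 4.8 to 6.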

Compound 3, distribution coefficient: 4.4
Compound 3: the middle estimate sits 1.00 log units above what was measured; the whole stated range lies above it.
By their numbers in this assay, from the lowest: compound 3; then compound 2; then compound 1.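

In this assay, going by these compounds alone, this position on the amide-type nitrogen allows a far larger move than the single modest step suggested: swapping in the group with 2 hydrogen-bond donors and an aromatic ring of carbon only gives a number 1.50 log units lower from compound 2 to compound 3 (beyond the scatter) and, over the series, a number 2.40 log units lower from compound 1 to compound 3 (beyond the scatter). Nothing shown gives a reason for the size of this drop.

The compounds shown do not separate the contribution of the added oxygen from that of the changed six-membered ring. Also open, going by these compounds, is how the number would respond to a methyl group on the entering group, or to a carboxylic acid in its place.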